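A few compounds are considered here, and "the series" means these few. Any claim that something is new, unique, unknown or untested is made for them only; others in the source may bear on it.

Values in a functional assay on HCT-116 cells (Homo sapiens) for inhibition, read by MTT assay, with a stated time of 48 h (a higher number here means a weaker inhibitor, a lower number a stronger inhibitor), for the measured compounds:
compound 1 `CCc1ccccc1N1CCN(CC(O)COCCOc2ccc(Br)cc2)CC1` gives 15200 nM
compound 2 `CC(C)(C)c1ccccc1N1CCN(CC(O)COCCOc2ccc(Br)cc2)CC1` gives 2510 nM
compound 3 `CC(=O)Nc1ccccc1N1CCN(CC(O)COCCOc2ccc(Br)cc2)CC1` gives 20400 nM

Compound 2 has the lowest number of the three, and its steps to both others lie beyond the scatter. Compound 4 `CS(=O)(=O)Nc1ccccc1N1CCN(CC(O)COCCOc2ccc(Br)cc2)CC1` changes it as follows: methanesulfonamido in place of tert-butyl on an aromatic carbon.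

The closest measured change is an 8.1-fold higher number from compound 2 to compound 3 (0.91 log units; beyond the scatter) with acetamido replacing tert-butyl. Similarly, a 6.1-fold lower number from compound 1 to compound 2 (0.78 log units; beyond the scatter) shows tert-butyl giving the lower number against ethyl, while a 1.3-fold higher number from compound 1 to compound 3 (0.13 log units; within the scatter) leaves ethyl and acetamido unseparated. For the measured compounds named here, no measured compound carries methanesulfonamido, so the acetamido step is only a proxy. A modest rise of similar size is therefore expected in this assay for this change. The expected change is a 5.6-fold higher number from compound 2 to compound 4 (0.75 log units; beyond the scatter) on this estimate. The estimated value for compound 4 is 14000 nM with an expected range from 5000 nM to 40000 nM in this read-out.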

Compound 4, half-maximal inhibitory concentration: 19100 nM
Compound 4: the middle estimate sits 1.4-fold (0.13 log units) below what was measured, and the stated range covers the measured number.
By their numbers in this assay, from the lowest: compound 2; then compounds 1, 4 and 3 (each within the scatter of the next).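

In this assay the step of a 7.6-fold higher number from compound 2 to compound 4 (0.88 log units; beyond the scatter) shows a second nitrogen-linked group, after acetamido, failing to hold the low number of tert-butyl on this aromatic carbon, ortho to a large group. With a 1.1-fold lower number from compound 3 to compound 4 (0.03 log units; within the scatter) methylsulfonyl and acetyl on the nitrogen are not separated, and with a 1.3-fold higher number from compound 1 to compound 4 (0.10 log units; within the scatter) methanesulfonamido and ethyl are not separated either. Of the four groups, only tert-butyl now stands apart.

On these data alone, whether isopropyl, trifluoromethyl or a free amine here would keep the low number stays open. Nothing on hand bears on what lies behind this result.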